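This account rests on a few compounds, and the source may have more. Where it says the series, first, only, none or still open, it means among the compounds named here.

Of the compounds shown here, three of one shared core have been measured in a functional assay on HCT-116 cells (Homo sapiens) for inhibition, read by MTT assay, with a stated time of 72 h; a higher number here means a weaker inhibitor, a lower number a stronger inhibitor. Compound 1 `CC1=NN(c2ccccc2)C(=O)[C@]12C(=O)C=CC[C@H]2c1ccccc1[N+](=O)[O-]` gives 11200 nM, compound 2 `CC1=NN(c2ccccc2)C(=O)[C@]12C(=O)C=CC[C@H]2c1cccc(C)c1` gives 9580 nM, and compound 3 `CC1=NN(c2ccccc2)C(=O)[C@]12C(=O)C=CC[C@H]2c1ccccc1` gives 5300 nM. Compound 3 carries the lowest number of the three: the step of a 2.1-fold lower number from compound 1 to compound 3 (0.32 log units; beyond the scatter) lies beyond the scatter, whereas the step of a 1.8-fold lower number from compound 2 to compound 3 (0.26 log units; within the scatter) and the step of a 1.2-fold lower number from compound 1 to compound 2 (0.07 log units; within the scatter) stay within it, so compound 3 and compound 2 cannot be told apart on these numbers.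

Compound 4 `CC1=NN(c2ccccc2)C(=O)[C@]12C(=O)C=CC[C@@H]2c1ccccc1` is the next compound. Its relation to compound 3 is the two compounds have the same atoms and bonds and differ only in configuration as drawn: 1 of 2 stereo elements differ; a stereocentre at a saturated ring carbon is drawn S in compound 3 and R in compound 4. None of the three measured steps concerns a change of configuration; each of them swaps a group on the aromatic ring, so none bears on the step to compound 4, and no size or direction can be read from them. The estimate for compound 4 therefore stays close to the number of compound 3, with a wide range: compound 4 is expected to give about 5300 nM, between 1500 nM and 20000 nM. The expected step is no change at the digits printed from compound 3 to compound 4 (within the scatter).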

Compound 4, half-maximal inhibitory concentration: 6040 nM
Compound 4: the middle estimate sits 1.1-fold (0.06 log units) below what was measured, within the range that was stated.
By their numbers in this assay, from the lowest: compounds 3, 4, 2 and 1 (each within the scatter of the next, the first and the last beyond it).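

In this assay, changing the stereocentre at a saturated ring carbon from S to R gives a 1.1-fold higher number from compound 3 to compound 4 (0.06 log units; within the scatter), so the two configurations cannot be told apart on these numbers. The earlier steps shown here only swapped groups on the aromatic ring, whereas this one shows that, with an unsubstituted phenyl group on that carbon, the assay does not resolve a change of configuration at this stereocentre. The reading concerns configuration alone: the fact that compounds 3 and 4 differ only in the configuration as drawn.

On these data alone, whether this also holds with the 2-nitrophenyl or 3-methylphenyl group on that carbon remains open, as does the effect of changing the second stereocentre, which is drawn alike in compound 3 and compound 4. As far as these compounds go, what an amine or a carboxylic acid on the aromatic ring would do is also open.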